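From tert-Butoxy to Dimethylamino on the Carbonyl Carbon

This account rests on a few compounds, and the source may have more. Where it says the series, first, only, none or still open, it means among the compounds named here.

Compound 1 `CC(C)(C)OC(=O)N1CCC[C@H]1C(=O)N1CCC(NS(=O)(=O)c2cc(S(=O)(=O)c3ccccc3)ccc2C(F)(F)F)CC1` was tested in an assay on isolated protein for binding affinity to secreted frizzled-related protein 1 (Homo sapiens), read by fluorescence (a higher number here means a weaker inhibitor, a lower number a stronger inhibitor), where compound 1 gives 60 nM. Among three measured compounds that number stands second highest: compound 3 `O=C([C@@H]1CCCN1C(=O)c1ccncc1)N1CCC(NS(=O)(=O)c2cc(S(=O)(=O)c3ccccc3)ccc2C(F)(F)F)CC1` gives 70 nM in this assay, and compound 2 `CC(C)(C)CC(=O)N1CCC[C@H]1C(=O)N1CCC(NS(=O)(=O)c2cc(S(=O)(=O)c3ccccc3)ccc2C(F)(F)F)CC1` gives 20 nM. Compound 4 `CN(C)C(=O)N1CCC[C@H]1C(=O)N1CCC(NS(=O)(=O)c2cc(S(=O)(=O)c3ccccc3)ccc2C(F)(F)F)CC1` differs from compound 1 in one place: dimethylamino in place of tert-butoxy on a carbonyl carbon. The same carbonyl carbon has been varied twice. Neopentyl brought a 3.0-fold lower number from compound 1 to compound 2 (0.48 log units; beyond the scatter), while pyridin-4-yl brought a 1.2-fold higher number from compound 1 to compound 3 (0.07 log units; within the scatter); between those two the gap was a 3.5-fold higher number from compound 2 to compound 3 (0.54 log units; beyond the scatter). Dimethylamino resembles neither, so compound 1 serves as the anchor, and for compound 4 a step within the scatter is expected, a 1.3-fold higher number from compound 1 to compound 4 (0.12 log units; within the scatter). Compound 4 is therefore estimated at 80 nM, with a range from 30 nM to 250 nM.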

Compound 4, half-maximal inhibitory concentration: 30 nM
For compound 4 the middle estimate is 2.7-fold (0.43 log units) above the measured one; low and high end bracket the measured number.
By their numbers in this assay, from the lowest: compounds 2, 4, 1 and 3 (each within the scatter of the next, the first and the last beyond it).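

In this assay, among these compounds, dimethylamino is the first group on this carbonyl carbon to stay within the scatter of both tert-butoxy and neopentyl, with a 2.0-fold lower number from compound 1 to compound 4 (0.30 log units; within the scatter) and a 1.5-fold higher number from compound 2 to compound 4 (0.18 log units; within the scatter) even though those two groups differ from each other by more than the scatter. Replacing pyridin-4-yl gives a 2.3-fold lower number from compound 3 to compound 4 (0.37 log units; beyond the scatter) and so this step is a real, though modest, one. No measurement here explains these steps. From the compounds shown here alone, whether methylamino or a ring amine such as morpholin-4-yl would keep the number in this range remains open.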